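Dimethyl for methoxy on the thiophene of a sulfonylurea

The source may report more compounds than this note shows. Statements on the series, on what has been measured and on what is new or still open speak of the compounds shown alone.

Compound 2 `COc1csc(S(=O)(=O)NC(=O)Nc2ccc(Cl)cc2)c1` holds the lower of the two numbers in a functional assay on the whole organism (6C3HED cells, Mus musculus) for inhibition, at a dose of 300 mg/kg by the oral route (on this read-out higher numbers stand for more inhibition at the one dose given (going by the name of the read-out) and lower numbers for less inhibition), where compound 2 gives 69%. Compound 1 `CCc1ccc(S(=O)(=O)NC(=O)Nc2ccc(Cl)cc2)s1` stands higher; in this assay compound 1 gives 89%. Among the compounds with values here, the single measured step runs a number 20 percentage points lower from compound 1 to compound 2 (beyond the scatter), so an alkyl-bearing ring outscored the methoxy-bearing one. Compound 3 `Cc1cc(S(=O)(=O)NC(=O)Nc2ccc(Cl)cc2)sc1C` carries the change (4,5-dimethylthiophen-2-yl in place of 4-methoxythiophen-2-yl on a sulfonyl sulfur). Since the change returns to an alkyl-only ring, a rise is expected; from compound 1 the step of a number 20 percentage points lower from compound 1 to compound 2 (beyond the scatter) gives its size. Compound 3 is therefore estimated at 82%, between 60% and 95%, an expected step of a number 13 percentage points higher from compound 2 to compound 3 (beyond the scatter).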

Compound 3, a percentage reported as inhibition, in the whole organism at one dose (the size of the read-out at that dose, not a potency): 73%
Beside the measured number, compound 3's estimate is 9 percentage points above it, and the stated range covers the measured number.
By their numbers in this assay, from the lowest: compounds 2 and 3 (each within the scatter of the next); then compound 1.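

In this assay, the step of a number 4 percentage points higher from compound 2 to compound 3 (within the scatter) shows that 4,5-dimethylthiophen-2-yl and 4-methoxythiophen-2-yl cannot be told apart at this position on the sulfonyl sulfur. An alkyl-only ring is therefore not enough to match 5-ethylthiophen-2-yl, as the step of a number 16 percentage points lower from compound 1 to compound 3 (beyond the scatter) makes plain. Nothing available explains this difference. Still open, on these data alone, is whether a 5-propylthiophen-2-yl ring, with its longer chain, would stand with compound 1 or with compound 3. An amine on the thiophene also remains untested among the compounds shown here.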